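A few compounds are considered here, and "the series" means these few. Any claim that something is new, unique, unknown or untested is made for them only; others in the source may bear on it.

Three chalcones have been tested in a functional assay on A549 cells (Homo sapiens) for cytotoxicity, read by sulforhodamine B assay, with a stated time of 48 h; a higher number here means a weaker inhibitor, a lower number a stronger inhibitor. Compound 1, `COc1ccc(/C=C/C(=O)c2cccc(Br)c2)cc1OC`, gives 9430 nM in this assay. Compound 2, `COc1cccc(/C=C/C(=O)c2cccc(-c3cccc(F)c3)c2)c1OC`, gives 8900 nM. Compound 3, `COc1ccccc1/C=C/C(=O)c1cccc(-c2cccc(F)c2)c1`, gives 15500 nM. The difference between the core of compound 1 and the core of compound 2 is not broken down here. Compound 2 and compound 3 share a core and differ in one place: hydrogen in place of methoxy on an aromatic carbon. That change made a step of a 1.7-fold higher number from compound 2 to compound 3 (0.24 log units; within the scatter), so the three numbers all sit close together, and none of the compounds can be called stronger or weaker than another on this evidence.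

Compound 4, `COc1ccc(/C=C/C(=O)c2cccc(Br)c2)cc1`, has not yet been measured. It is related to compound 1 by the same change, (hydrogen in place of methoxy on an aromatic carbon), with the surroundings of the place described in the same words as for the pair of compound 2 and compound 3. Among the measured compounds shown here, with only one earlier example of this change to go on, the expectation for compound 4 rests on that single step: the number is expected to move by about a 1.5-fold higher number from compound 1 to compound 4 (0.17 log units; within the scatter) in this assay, a step of the same kind and size as the one from compound 2 to compound 3, and well inside the usual spread of repeated measurements. On that basis compound 4 is estimated at 14000 nM in this assay, with a plausible range from 6000 nM to 32000 nM.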

Compound 4, half-maximal inhibitory concentration: 34200 nM
Compound 4: the middle estimate sits 2.4-fold (0.39 log units) below what was measured; measured number above the stated range.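

Putting hydrogen in place of the methoxy group made the compound a weaker inhibitor in this assay, with a 3.6-fold higher number from compound 1 to compound 4 (0.56 log units; beyond the scatter), so on this core the loss of the group can be told apart from ordinary repeat-to-repeat variation. Set beside the earlier example, the change raises the number on both cores, and the two steps cannot be told apart in size, even though only the newer one stands clear of the scatter on its own: the same change on two cores in this assay, a 1.7-fold higher number (0.24 log units; within the scatter) from compound 2 to compound 3 and a 3.6-fold higher number (0.56 log units; beyond the scatter) from compound 1 to compound 4, 2.1-fold (0.32 log units) apart, within the scatter of two such steps. This supports carrying the change from one core to the other as a rough expectation of a move in the same direction, but two pairs do not establish a rule for the whole series, and they do not show that the core of compound 1 responds more strongly than the other core.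

The compounds shown leave open whether the methoxy group matters as such or whether other groups at the same place, such as a hydroxyl group, an amine or a longer ethoxy chain, would hold the number as well. They also leave open whether the same step would appear on cores other than these two, or in cells other than the ones used here.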